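The source may report more compounds than this note shows. Statements on the series, on what has been measured and on what is new or still open speak of the compounds shown alone.

The set rests on one shared core. Compound 1 `O=C1NCCc2nc(C#Cc3ccccc3F)sc21` gives 1500 nM in an assay on HEK293 cells for positive allosteric modulation of metabotropic glutamate receptor 5 (Homo sapiens), read by FLIPR, with a stated time of 1 h; on this read-out higher numbers stand for an effect only at larger amounts of compound and lower numbers for an effect already at smaller amounts. For compound 2 `CN1CCc2nc(C#Cc3cccc(F)c3)sc2C1` this assay reports only a limit, > 10000 nM. For compound 3 `CCC(=O)N1CCc2nc(C#Cc3ccccc3)sc2C1` this assay likewise reports only a limit, > 10000 nM. Compound 3 thus stands at the limit of > 10000 nM in this assay, at which 2 of the 3 values shown sit, where compound 2 also sits, while compound 1 alone gives a number within the measured range. Compound 4 `O=C(CC1CCOCC1)N1CCc2nc(C#Cc3ccccc3)sc2C1` has not yet been measured; it differs from compound 3 by oxan-4-yl in place of methyl on a saturated chain carbon bound to a carbonyl carbon. Going by the values given here, no two measured compounds differ in a single place, so no measured step exists to lean on. Because compound 3 sits at the limit of > 10000 nM in this assay, at which 2 of the 3 values shown sit, any movement toward smaller amounts would have to be large before it showed as a number, and the step is expected to be small, an at least 1.2-fold lower number from compound 3 to compound 4 (0.09 log units; that floor lies within the scatter), in the direction of smaller amounts if anything. Compound 4 is therefore estimated at 8000 nM, with a range from 1500 nM to 30000 nM, and a fair chance that this assay again reports only a limit.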

Compound 4, half-maximal effective concentration: 470 nM
The estimate for compound 4 lay 17-fold (1.23 log units) above the measured number; the measured number lies below the stated range.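

In this assay, oxan-4-yl in place of methyl on a saturated chain carbon bound to a carbonyl carbon gives an at least 21-fold lower number from compound 3 to compound 4 (1.32 log units; beyond the scatter). Going by these compounds alone, the earlier compounds offered no measured step at all, so this is the first sign that a change at this one place can carry a compound from a limit to a number, and that the place accepts one six-membered non-aromatic ring with 1 hetero atom where a single carbon stood. The step has only a floor, and its full size stays unfixed, since compound 3 stands at a limit: the limit of > 10000 nM in this assay, at which 2 of the 4 values shown sit.

The compounds shown leave open whether the ring, its oxygen or the added length carries the change, which a cyclohexyl group or a plain longer chain at this place would help to separate. They also leave open how a ring amine such as piperidin-4-yl would read here.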